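Swapping the Amine on a Dithiocarbamate Side Chain

The source may hold more compounds than are shown below. What is called first, only, known or untested is meant among the compounds shown, and "the series" means these compounds.

Measured so far:
- compound 1, `Cc1ccc2c(=O)c(CSC(=S)N3CCCCC3)coc2c1`: 1700 nM
- compound 2, `O=c1c(CSC(=S)N2CCCCC2)coc2cc(Cl)ccc12`: 240 nM

Both compounds were tested in a functional assay on MDA-MB-435S cells (Homo sapiens) for antiproliferative activity, read by MTT assay, with a stated time of 72 h; a higher number here means a weaker inhibitor, a lower number a stronger inhibitor. Compound 1 gives the higher of the two numbers: the step of a 7.1-fold lower number from compound 1 to compound 2 (0.85 log units; beyond the scatter) is the only one recorded, and it concerns the group on the aromatic ring, not the side chain.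

Compound 3, `Cc1ccc2c(=O)c(CSC(=S)N(C(C)C)C(C)C)coc2c1`, has not yet been measured. It differs from compound 1 by diisopropylamino in place of piperidin-1-yl on a thiocarbonyl carbon. Among the measured compounds shown here, no measured step touches this part of the molecule, so the only step on record says nothing about the likely effect. The expectation is therefore a number close to that of compound 1, with no step beyond the scatter in either direction.

The estimate for compound 3 is 1700 nM, within 600 nM to 5000 nM, which corresponds to an expected step of no change at the digits printed from compound 1 to compound 3 (within the scatter).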

Compound 3, half-maximal inhibitory concentration: 240 nM
Estimate against measurement, compound 3: 7.1-fold (0.85 log units) above; measured number below the stated range.
By their numbers in this assay, from the lowest: compounds 2 and 3 (each within the scatter of the next); then compound 1.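

In this assay, the amine on the side chain turns out to matter: diisopropylamino in place of piperidin-1-yl on a thiocarbonyl carbon gives a 7.1-fold lower number from compound 1 to compound 3 (0.85 log units; beyond the scatter). Among the compounds shown here, the earlier step concerned only the group on the aromatic ring, so this is the first sign that a change on the side chain can also move the number beyond the scatter. The swap replaces a six-membered non-aromatic ring with a group that has no ring, while neither group has hydrogen-bond donors, acceptors or a net charge, and no measurement here explains the result.

A single pair cannot show whether losing the ring or adding the branched isopropyl groups goes with the lower number, and diethylamino or pyrrolidin-1-yl at this place could help separate the two. On these data alone, it also remains open whether diisopropylamino would give a similar step with chloro in place of methyl on the aromatic ring.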